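Cytotoxicity of acylthiourea variants on a shared core

This account rests on a few compounds, and the source may have more. Where it says the series, first, only, none or still open, it means among the compounds named here.

Compound 1 `CN(c1cc2ncc(=O)[nH]c2cc1NC(=S)NC(=O)c1ccccc1)C1CCCCC1` gives 11100 nM in an ADME assay on Huh-7 cells (Homo sapiens) for cytotoxicity; on this read-out higher numbers stand for weaker inhibition and lower numbers for stronger inhibition.
Compound 2 `CN(c1cc2ncc(=O)[nH]c2cc1NC(=S)NC(=O)c1ccc(OC(F)(F)F)cc1)C1CCCCC1` gives 6470 nM in this assay.
Compound 3 `CN(c1cc2ncc(=O)[nH]c2cc1NC(=S)NC(=O)/C=C/c1ccccc1)C1CCCCC1` gives 11000 nM in this assay.

The three measured compounds share one core and differ only in the group on the carbonyl carbon of the acylthiourea. All three numbers lie within the scatter of one another. Compound 3 sits alongside compound 1, with a 1.0-fold lower number from compound 1 to compound 3 (0.00 log units; within the scatter), and within the scatter of compound 2, with a 1.7-fold higher number from compound 2 to compound 3 (0.23 log units; within the scatter). The step from hydrogen to trifluoromethoxy on the aromatic carbon, a 1.7-fold lower number from compound 1 to compound 2 (0.23 log units; within the scatter), likewise stays within the scatter.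

Compound 4 `CN(c1cc2ncc(=O)[nH]c2cc1NC(=S)NC(=O)c1ccc(Cl)nc1)C1CCCCC1` has not yet been measured in this assay. It differs from compound 3 by 6-chloropyridin-3-yl in place of 2-phenylethenyl on a carbonyl carbon. The two measured steps that bear on this position, a 1.0-fold lower number from compound 1 to compound 3 (0.00 log units; within the scatter) and a 1.7-fold higher number from compound 2 to compound 3 (0.23 log units; within the scatter), both change the group on the carbonyl carbon and neither moved the number beyond the scatter. Going by the values given here, no measured step shows a pyridine ring or a chlorine at this place, so the expectation rests on the spread already seen. Compound 4 is therefore expected to give a number close to that of compound 3, a step of a 1.1-fold lower number from compound 3 to compound 4 (0.04 log units; within the scatter) that stays within the scatter. The estimate for compound 4 in this assay is 10000 nM, with a range from 4000 nM to 25000 nM.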

Compound 4, half-maximal inhibitory concentration: 34500 nM
Estimate against measurement, compound 4: 3.5-fold (0.54 log units) below; measured number outside the range, above it.
By their numbers in this assay, from the lowest: compounds 2, 3 and 1 (each within the scatter of the next); then compound 4.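

In this assay, the group on the carbonyl carbon can move the number beyond the scatter, which none of the earlier changes at this place had done: 6-chloropyridin-3-yl gives a higher number against 2-phenylethenyl (a 3.1-fold higher number from compound 3 to compound 4 (0.50 log units; beyond the scatter)), against phenyl (a 3.1-fold higher number from compound 1 to compound 4 (0.49 log units; beyond the scatter)) and against 4-(trifluoromethoxy)phenyl (a 5.3-fold higher number from compound 2 to compound 4 (0.73 log units; beyond the scatter)). Going by these compounds alone, compound 4 therefore stands apart from the other three compounds, with the highest number of the set, and the tolerance suggested by the earlier compounds does not extend to every group at this place. The step from compound 1 replaces a ring of carbon only with a ring holding one hetero atom and also brings in a chlorine, and nothing available explains why this change raises the number.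

The compounds shown leave open whether the ring nitrogen, the chlorine or only the two together produce the step, which a plain pyridin-3-yl and a 4-chlorophenyl group could separate. They also leave open how this place responds to an amine or a carboxylic acid on the ring, or to a saturated alkyl chain on the carbonyl carbon.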